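The source may report more compounds than this note shows. Statements on the series, on what has been measured and on what is new or still open speak of the compounds shown alone.

Measured compounds: compound 1, `Cn1c(C(=O)NCc2ccc(S(=O)(=O)c3ccccc3)cc2)cc2cnccc21`, gives 34% in an ADME assay on microsomes from liver (Mus musculus) for metabolic stability, read by LC-MS, with a stated time of 30 min, tested at 1 uM; a lower number here means that less of the compound is left, a higher number that more of the compound is left; compound 2, `Cc1cccc(S(=O)(=O)c2ccc(CNC(=O)c3cc4cnccc4[nH]3)cc2)c1`, gives 32% in this assay. Compound 3, `Cn1c(C(=O)NCc2ccc(S(=O)(=O)c3ccccc3)cc2)cc2ccncc21`, gives no single number in this assay; its entry reads "below limit of detection" (no number reported).

Compound 2 and compound 1 lie within the scatter of each other, so the two numbers do not separate them. Compound 4, `O=C(NCc1ccc(S(=O)(=O)c2cccc(F)c2)cc1)c1cc2cnccc2[nH]1`, differs from compound 2 by fluoro in place of methyl on an aromatic carbon. For the measured compounds named here, no step between measured compounds covers this change, so there is little to lean on. The change is small in size, and the expectation for this assay is a step from compound 2 to compound 4 of modest extent upward, a number 8 percentage points higher from compound 2 to compound 4 (within the scatter), which may still sit within the scatter. Compound 4 is therefore estimated at 40%, with a range from 25% to 58%.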

Compound 4, percent of the compound remaining: 44%
Compound 4: the middle estimate sits 4 percentage points below what was measured, and the stated range covers the measured number.
By their numbers in this assay, from the lowest: compounds 2, 1 and 4 (each within the scatter of the next, the first and the last beyond it).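

Replacing 3-methylphenyl with 3-fluorophenyl gives, in this assay, a number 12 percentage points higher from compound 2 to compound 4 (beyond the scatter) as the first step in one place among these compounds. It shows that the percent remaining responds at this position to an exchange of one heavy atom for another. No available measurement bears on why the number moves. Still open, from the compounds shown here alone, is how other groups at this place, such as chloro, methoxy or an amine, would compare with fluoro. Also open, going by these compounds, is whether the same exchange would give a similar step on the core of compound 1.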